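Swapping a nitro ring for a chlorophenyl-ethenyl chain

This account rests on a few compounds, and the source may have more. Where it says the series, first, only, none or still open, it means among the compounds named here.

Compound 3 `O=C(Nc1cc(Sc2ncn[nH]2)c(O)c2ccccc12)c1cccc([N+](=O)[O-])c1` gives 26900 nM in a functional assay on PC-3 cells (Homo sapiens) for antiproliferative activity, read by MTT assay, with a stated time of 48 h (a lower number here means a stronger inhibitor, a higher number a weaker inhibitor), the lowest number of the three measured compounds. Compound 2 `Cc1cccc(C(=O)Nc2cc(Sc3ncn[nH]3)c(O)c3ccccc23)c1` gives 59500 nM and compound 1 `O=C(Nc1cc(Sc2ncn[nH]2)c(O)c2ccccc12)c1cccc(Cl)c1` gives 85600 nM. The steps of a 3.2-fold lower number from compound 1 to compound 3 (0.50 log units; beyond the scatter) and a 2.2-fold lower number from compound 2 to compound 3 (0.34 log units; beyond the scatter) set compound 3 apart as the strongest inhibitor here, while a 1.4-fold lower number from compound 1 to compound 2 (0.16 log units; within the scatter). Compound 4 `O=C(/C=C/c1ccc(Cl)cc1)Nc1cc(Sc2ncn[nH]2)c(O)c2ccccc12` differs from compound 3 in one place: 2-(4-chlorophenyl)ethenyl in place of 3-nitrophenyl on a carbonyl carbon. Going by the values given here, the measured steps bear on this only in part: read backwards, both show that taking away the nitro group raises the number modestly, but no measured step covers the 2-(4-chlorophenyl)ethenyl group itself. The change expected is a 1.9-fold higher number from compound 3 to compound 4 (0.27 log units; within the scatter). Compound 4 is therefore estimated at 50000 nM, within 15000 nM to 170000 nM.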

Compound 4, half-maximal inhibitory concentration: > 100000 nM
Compound 4 gave a limit, no number; the forecaster's own chance of this, stated with the estimate: 10%; middle value at least 2.0-fold (0.30 log units) from the limit.
By their numbers in this assay, from the lowest: compound 3; then compounds 2 and 1 (each within the scatter of the next). At a limit, above all of these: compound 4.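

Compound 4 stands at a limit of the assay, not at a number: the limit of > 100000 nM in this assay, at which 1 of the 4 values shown sits. Putting 2-(4-chlorophenyl)ethenyl in place of 3-nitrophenyl on the carbonyl carbon gives an at least 3.7-fold higher number from compound 3 to compound 4 (0.57 log units; beyond the scatter), so a group with the same heavy-atom count does not keep the activity of compound 3. The other two steps, an at least 1.6-fold higher number from compound 2 to compound 4 (0.22 log units; that floor lies within the scatter) and an at least 1.1-fold higher number from compound 1 to compound 4 (0.06 log units; that floor lies within the scatter), have floors within the scatter, so compound 4 is not shown to be weaker than compound 2 or compound 1.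

The compounds shown leave open whether the ethenyl link or the chloro group goes with the loss. They also leave open whether an amine or a carboxylic acid on the phenyl ring would give a lower number than compound 3.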